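A Larger Amide Group on the Core of Compound 1

This account rests on a few compounds, and the source may have more. Where it says the series, first, only, none or still open, it means among the compounds named here.

Measured compounds:
Compound 1 `CC(C)C1=C(C(=O)N2[C@H](C)CC[C@H]2C(=O)N2CCN(C)CC2)SC2=N[C@@](C)(c3ccc(Cl)cc3)[C@@H](c3ccc(Cl)cc3)N21` gives 190 nM in a functional assay on MV4-11 cells (Homo sapiens) for inhibition, read by luminescence, with a stated time of 3 days; a higher number here means a weaker inhibitor of growth, a lower number a stronger inhibitor of growth.
Compound 2 `CC[C@@H]1CC[C@@H](C(=O)N2CCOCC2)N1C(=O)C1=C(C(C)C)N2C(=N[C@@](C)(c3ccc(Cl)cc3)[C@H]2c2ccc(Cl)cc2)S1` gives 94 nM in this assay .

Of the two numbers measured, compound 1 has the higher one, so among these it is the weaker inhibitor of growth; compound 2 has the lower number, and that gap lies beyond the usual scatter. Compound 3 `CC(C)C1=C(C(=O)N2[C@H](C)CC[C@H]2C(=O)N2CCN(C)C(C)(C)C2)SC2=N[C@@](C)(c3ccc(Cl)cc3)[C@@H](c3ccc(Cl)cc3)N21` comes from compound 1 by a single change, (a group of 9 heavy atoms (7 carbon, 2 nitrogen; one six-membered non-aromatic ring with 2 hetero atoms) in place of a group of 7 heavy atoms (5 carbon, 2 nitrogen; one six-membered non-aromatic ring with 2 hetero atoms), on a carbonyl carbon). Within the data shown here, no measured pair shows what such a change alone does in this assay, and compound 1 and compound 2 differ in several places at once, so their two values show nothing about this one step. The change is small in extent, and a step of modest size is expected, most likely within the scatter and with no clear direction: the step from compound 1 to compound 3 is estimated at a 1.1-fold higher number from compound 1 to compound 3 (0.04 log units; within the scatter). Compound 3 is expected to give about 210 nM, with a likely range from 80 nM to 550 nM.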

Compound 3, concentration for 50% growth inhibition: 280 nM
Compound 3: the middle estimate sits 1.3-fold (0.12 log units) below what was measured, within the range that was stated.
By their numbers in this assay, from the lowest: compound 2; then compounds 1 and 3 (each within the scatter of the next).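

With the 4-methylpiperazin-1-yl group on the carbonyl carbon replaced by the larger ring of 9 heavy atoms, this assay shows a 1.5-fold higher number from compound 1 to compound 3 (0.17 log units; within the scatter). Among these compounds, this is the first single-place comparison at this position, and it shows that this enlargement of the ring group leaves compound 3 indistinguishable from compound 1 in this measurement, with the hydrogen-bond donor and acceptor counts and the net charge unchanged. Nothing measured here offers an explanation for this result.

One step at one position cannot show how far this tolerance extends. On these data alone, it remains open whether a piperazin-1-yl ring with a free amine hydrogen, or an open-chain dimethylamino group on the same carbonyl carbon, would also stay within the scatter of compound 1.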